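The source may report more compounds than this note shows. Statements on the series, on what has been measured and on what is new or still open speak of the compounds shown alone.

The measured compounds and their values in a functional assay on RXF 393 cells (Homo sapiens) for inhibition, read by sulforhodamine B assay, with a stated time of 48 h; on this read-out lower numbers stand for stronger inhibition of growth and higher numbers for weaker inhibition of growth:

compound 1, `Nc1cc(N)c2nc(-c3ccccc3)c(NCc3ccc(Cl)c(Cl)c3)nc2c1`: 17000 nM
compound 2, `CCOC(=O)[C@H](CCC(=O)O)NC(=O)c1ccc(Sc2nc3cc(N)cc(N)c3nc2-c2ccccc2)cc1`: 74100 nM
compound 3, `COc1cc(CNc2nc3cc(N)cc(N)c3nc2-c2ccccc2)cc(OC)c1OC`: 20000 nM

Compound 1 and compound 3 give numbers in this assay that lie within the usual scatter of each other, so nothing separates them on these data. Compound 2 gives a number that lies beyond the scatter on the side of weaker inhibition of growth. No two of the measured compounds differ in a single place, so no step can be read directly from the measured set, and the three values show only where each compound sits.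

Compound 4, `Nc1cc(N)c2nc(-c3ccccc3)c(NCc3ccc(F)cc3)nc2c1`, has not been measured. It differs from compound 1 in one place: 4-fluorophenyl in place of 3,4-dichlorophenyl on a saturated chain carbon bound to a nitrogen on an aromatic ring. The shared core of compound 1 and the linkage through the chain carbon and nitrogen are unchanged.

Going by the values given here, with no measured step of this kind to draw on, the expectation rests on compound 1 alone, which gives 17000 nM in this assay. A modest step is expected from compound 1 to compound 4, toward weaker inhibition of growth, and it may well stay within the scatter; the expected step is a 1.5-fold higher number from compound 1 to compound 4 (0.17 log units; within the scatter). Compound 4 is therefore estimated at 25000 nM in this assay, within a range from 10000 nM to 60000 nM.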

Compound 4, concentration for total growth inhibition: 26900 nM
Compound 4: middle estimate off by 1.1-fold (0.03 log units), on the low side; the measured number falls inside the stated range.
By their numbers in this assay, from the lowest: compounds 1, 3 and 4 (each within the scatter of the next); then compound 2.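

In this assay, going by these compounds alone, the exchange of 3,4-dichlorophenyl for 4-fluorophenyl on a saturated chain carbon bound to a nitrogen on an aromatic ring gives a 1.6-fold higher number from compound 1 to compound 4 (0.20 log units; within the scatter) and is the first step in this set that can be read directly. It shows that this one exchange at this position, which removes both chlorine atoms and brings in one fluorine on the same six-membered aromatic ring of carbon, does not separate the two compounds on this read-out. No measured property bears on this result.

The compounds shown leave open whether any other group at this position would give a step beyond the scatter, since this single exchange keeps the aromatic ring of carbon and adds no hydrogen-bond donors or acceptors. On these data alone, how a carboxylic acid or an amine on that ring, or a longer chain joining the ring to the nitrogen, would read in this assay also remains open.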